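Working notes: lipophilicity from compound 1 to compound 3

The source may hold more compounds than are shown below. What is called first, only, known or untested is meant among the compounds shown, and "the series" means these compounds.

Compound 1 (`CN(CC(N)=O)c1c(C#N)c(-c2ccc(Br)cc2)nc2cnccc12`) gives 2.1 in a physicochemical assay for lipophilicity, read by HPLC, at pH 7.5 (on this read-out higher numbers stand for higher lipophilicity and lower numbers for lower lipophilicity), and compound 2 (`CC[C@@H](Nc1c(C#N)c(-c2ccc(-c3ccccc3CO)cc2)nc2cnccc12)C(N)=O`) gives 2.1 in this assay as well, so the two stand level within the scatter. Going by the values given here, no measured pair differs in one place only, and no measured step is available to carry over.

Compound 3 (`CC(Nc1c(C#N)c(-c2ccc(Br)cc2)nc2cnccc12)C(N)=O`) has the same atoms as compound 1, joined differently. The change ((1-carbamoylethyl)amino in place of (carbamoylmethyl)(methyl)amino on an aromatic carbon) puts (1-carbamoylethyl)amino in place of (carbamoylmethyl)(methyl)amino on an aromatic carbon, ortho to a cyano group and opposite the ring nitrogen, while the 4-bromophenyl group stays.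

Among the compounds with values here, with no measured step to guide it, the expectation in this assay is for no shift beyond the scatter, with only a weak lean upward. The expected step is small (a number 0.10 log units higher from compound 1 to compound 3 (within the scatter)) and is estimated to stay within the scatter. The starting point for this expectation is compound 1 at 2.1 as its reading. For compound 3 the estimated value is 2.2 as the middle, with an expected range from 1.8 to 2.6 in this series.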

Compound 3, distribution coefficient: 2.1
Compound 3: middle estimate off by 0.10 log units, on the high side, within the range that was stated.
By their numbers in this assay, from the lowest: compounds 1, 2 and 3 (each within the scatter of the next).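

In this assay, going by these compounds alone, putting (1-carbamoylethyl)amino in place of (carbamoylmethyl)(methyl)amino on the aromatic carbon opposite the ring nitrogen, ortho to the cyano group, gives the first one-place step, no change at the digits printed from compound 1 to compound 3 (within the scatter), with the 4-bromophenyl group unchanged. Compounds 1 and 2 stood level but differed in more than one place, so their values could say nothing about this position alone; this step shows that, with the 4-bromophenyl group in place, this read-out does not separate these two arrangements of the same atoms, even though the two groups differ in hydrogen-bond donor count. No measurement available here offers an explanation for this result.

On these data alone, it remains open whether the reading would hold with an amine or a carboxylic acid in place of the terminal amide at this position, or with a longer chain on the carbon bearing the amide. Also open, as far as these compounds go, is whether the same swap would read alike on a compound carrying the biaryl group of compound 2 in place of the 4-bromophenyl group.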